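Ethynyl Added on the Selenium-Bound Chain of Compound 2

The source may report more compounds than this note shows. Statements on the series, on what has been measured and on what is new or still open speak of the compounds shown alone.

Measured compounds:
- compound 1, `OCC#CCSc1cnc2ccccc2c1[Se]CC#CCO`, gives 1.4 ug/mL in a functional assay on CCRF-CEM cells (Homo sapiens) for cytotoxicity, read by sulforhodamine B assay, with a stated time of 72 h; on this read-out higher numbers stand for weaker inhibition and lower numbers for stronger inhibition
- compound 2, `C[Se]c1c(SCC#CCO)cnc2ccccc12`, gives 2.1 ug/mL in this assay

Compound 2 holds the highest of the two numbers in this assay, but its nearest neighbour is compound 1, and the step of a 1.5-fold higher number from compound 1 to compound 2 (0.18 log units; within the scatter) is within the scatter, so the two compounds cannot be told apart.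

Compound 3, `C#CC[Se]c1c(SCC#CCO)cnc2ccccc12`, has not yet been measured. It differs from compound 2 in one place: ethynyl in place of hydrogen on a saturated chain carbon bound to a selenium atom. Within the data shown here, the one measured step that touches this chain, a 1.5-fold higher number from compound 1 to compound 2 (0.18 log units; within the scatter), removed a larger group from the same carbon and changed the number by less than the scatter. Putting a smaller group back is therefore expected to move the number little, if at all, perhaps slightly downward.

Compound 3 is thus estimated at 1.7 ug/mL in this assay, with a range from 0.8 ug/mL to 3.6 ug/mL, an expected step of a 1.2-fold lower number from compound 2 to compound 3 (0.09 log units; within the scatter).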

Compound 3, concentration for 50% inhibition: 1.9 ug/mL
Estimate against measurement, compound 3: 1.1-fold (0.05 log units) below; the range from low to high includes it.
By their numbers in this assay, from the lowest: compounds 1, 3 and 2 (each within the scatter of the next).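

In this assay, ethynyl in place of hydrogen on a saturated chain carbon bound to a selenium atom gives a 1.1-fold lower number from compound 2 to compound 3 (0.04 log units; within the scatter), so the methyl and propargyl compounds cannot be told apart. Hydrogen in place of hydroxymethyl on a triple-bonded carbon gives a 1.4-fold higher number from compound 1 to compound 3 (0.13 log units; within the scatter), so removing the hydroxymethyl from this chain also produces no readable step. Across these three compounds, the selenium-bound chain can therefore differ in these ways without a difference beyond the scatter, though that holds only for compounds 1, 2 and 3. No separate measurement bears on this result.

From the compounds shown here alone, it remains open whether an amine or a carboxylic acid on this chain would give a step beyond the scatter. Going by these compounds, the chain on the sulfur atom is the same in all three compounds, so what it contributes also stays open.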